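From Trifluoromethyl to Methyl in a Cytotoxic Series

This account rests on a few compounds, and the source may have more. Where it says the series, first, only, none or still open, it means among the compounds named here.

Three compounds have numbers or limits in a functional assay on NCI-H460 cells (Homo sapiens) for cytotoxicity, read by MTT assay, with a stated time of 68 h; a higher number here means a weaker inhibitor, a lower number a stronger inhibitor. Compound 1 `COc1ccc(-c2cc(NC(=O)C(Cl)Cl)cc(-c3ccc(OC)c(F)c3)c2)cc1F` gives 1760 nM. Compound 2 `Nc1cccc(-c2cccc(NC(=O)C(Cl)Cl)c2)c1` is recorded at > 50000 nM, which is a limit of the assay and not a number. Compound 3 `O=C(Nc1cccc(-c2ccccc2C(F)(F)F)c1)C(Cl)Cl` gives 7550 nM, the higher of the two true numbers, and its gap to compound 1 lies beyond the usual scatter.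

Compound 4 `Cc1ccccc1-c1cccc(NC(=O)C(Cl)Cl)c1` has not yet been measured in this assay. It differs from compound 3 in one place, with methyl in place of trifluoromethyl on an aromatic carbon, ortho to a large group (methyl in place of trifluoromethyl on an aromatic carbon). Going by the values given here, no measured pair here shows this swap, so the forecast starts from compound 3 at 7550 nM and stays broad. The expected step, a 1.3-fold higher number from compound 3 to compound 4 (0.12 log units; within the scatter), stays within the scatter, with a slight lean toward a weaker inhibitor. For compound 4 the estimated value is 10000 nM, with an expected range from 3500 nM to 30000 nM.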

Compound 4, half-maximal inhibitory concentration: 31600 nM
For compound 4 the middle estimate is 3.2-fold (0.50 log units) below the measured one; the whole stated range lies below it.
By their numbers in this assay, from the lowest: compound 1; then compound 3; then compound 4. At a limit, above all of these: compound 2.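

In this assay, this position is sensitive to the group it carries: methyl in place of trifluoromethyl, ortho to a large group, gives a 4.2-fold higher number from compound 3 to compound 4 (0.62 log units; beyond the scatter). Going by these compounds alone, the earlier compounds held no pair differing in one place, so this is the first direct reading of a single change, and here trifluoromethyl goes with the stronger inhibitor. Within the data shown here, compound 2 is the only compound held at a limit of the assay, which is not a number: the limit of > 50000 nM in this assay, at which 1 of the 4 values shown sits.

This single swap shows the size of the change, but not what causes it, as nothing here measures what either group does. Going by these compounds, a chlorine atom or a nitrile at the same place could show whether trifluoromethyl is unusually favourable or methyl unusually poor, and whether the step holds on other cores remains open.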